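The source may report more compounds than this note shows. Statements on the series, on what has been measured and on what is new or still open speak of the compounds shown alone.

Within the data shown here, compound 1, `COc1ccc(/C=C/C(=O)c2ccc(OC)c3c2OC(C)(C)C=C3)c(F)c1`, carries the only number among the three values in a functional assay on HepG2 cells (Homo sapiens) for antiproliferative activity, read by MTT assay, with a stated time of 24 h; a higher number here means a weaker inhibitor, a lower number a stronger inhibitor; in this assay compound 1 gives 7560 nM. Compound 2, `COc1ccc(C(=O)/C=C/c2ccco2)c2c1C=CC(C)(C)O2`, reaches only the limit > 10000 nM in this assay. Compound 3, `COc1ccc(C(=O)/C=C/c2cccs2)c2c1C=CC(C)(C)O2`, likewise gives the limit > 10000 nM in this assay. Both of these sit at the limit of > 10000 nM in this assay, at which 2 of the 3 values shown sit. Compound 4 is `COc1ccc(C(=O)/C=C/c2ccccc2Cl)c2c1C=CC(C)(C)O2`, and it differs from compound 1 by 2-chlorophenyl in place of 2-fluoro-4-methoxyphenyl on a double-bonded chain carbon bound to a double-bonded chain carbon. The measured steps that bear on this change both swap the group on that chain carbon: an at least 1.3-fold higher number from compound 1 to compound 2 (0.12 log units; that floor lies within the scatter) and an at least 1.3-fold higher number from compound 1 to compound 3 (0.12 log units; that floor lies within the scatter). Neither step is readable beyond the scatter, so for compound 4 no step beyond the scatter is expected in this assay, with a real chance of another limit. Compound 4 is therefore expected to give about 12000 nM, between 5000 nM and 30000 nM. That expectation corresponds to a 1.6-fold higher number from compound 1 to compound 4 (0.20 log units; within the scatter).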

Compound 4, half-maximal inhibitory concentration: > 10000 nM
Compound 4 gave a limit, no number (the forecaster's own chance of this, stated with the estimate: 55%); the middle value does not contradict the limit.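

In this assay, among these compounds, compound 4 gives a limit, not a number, so the limit now covers 2-chlorophenyl on this chain carbon as well as furan-2-yl and thiophen-2-yl: the limit of > 10000 nM in this assay, at which 3 of the 4 values shown sit. The only step with a readable size is an at least 1.3-fold higher number from compound 1 to compound 4 (0.12 log units; that floor lies within the scatter). The steps among the three limit values cannot be read.

As far as these compounds go, the true values of compound 2, compound 3 and compound 4 remain open, so they cannot be ranked. Also open, from the compounds shown here alone, is how a phenyl group carrying an amine or a carboxylic acid at this place would read in this assay.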